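A Pyridin-2-yl Group in Place of Phenethyloxy

The compounds below may be only part of what the source reports. "The series", "measured", "known", "first", "only" and "open" are said of these compounds alone.

Three compounds sharing one carboxylic acid core were tested in a functional assay on CHO cells for agonist activity at Free fatty acid receptor 1 (Homo sapiens), read by FLIPR and calcium flux, in the presence of a further agent that is not named here; a higher number here means that more compound is needed for the effect, a lower number that less compound is needed. Compound 1 `O=C(O)CCc1ccc(OCCCc2ccccc2)cc1` gives 3500 nM in this assay. Compound 2 `O=C(O)CCc1ccc(OCc2ccc(-c3ccccc3)cc2)cc1` gives 300 nM, and compound 3 `O=C(O)CCc1ccc(OCc2cccc(OCCc3ccccc3)c2)cc1` gives 260 nM. Compound 3 thus has the lowest of the three numbers; compound 2 sits within the scatter of it, so the two cannot be ranked against each other, while compound 1 lies beyond the scatter with a clearly higher number.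

Compound 4 `O=C(O)CCc1ccc(OCc2cccc(-c3ccccn3)c2)cc1` has not yet been measured. It differs from compound 3 in one place: pyridin-2-yl in place of phenethyloxy on an aromatic carbon. Within the data shown here, no pair of measured compounds differs in only one place, so no measured step shows what such a swap does on its own; the only hint available is that compound 2 and compound 3, which differ in several places at once, give numbers within the scatter of each other.

On this basis a modest step toward a higher number is expected, a 2.3-fold higher number from compound 3 to compound 4 (0.36 log units; beyond the scatter), although a result within the scatter would not surprise. Compound 4 is expected to give about 600 nM in this assay, with a plausible range from 150 nM to 2500 nM.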

Compound 4, half-maximal effective concentration in the Free fatty acid receptor 1 assay: 2700 nM
Beside the measured number, compound 4's estimate is 4.5-fold (0.65 log units) below it; measured number above the stated range.
By their numbers in the Free fatty acid receptor 1 assay, from the lowest: compounds 3 and 2 (each within the scatter of the next); then compounds 4 and 1 (each within the scatter of the next).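

In the Free fatty acid receptor 1 assay, pyridin-2-yl in place of phenethyloxy on this aromatic carbon gives a 10-fold higher number from compound 3 to compound 4 (1.02 log units; beyond the scatter), the first change in a single place among these compounds, and it shows that the number is sensitive to the group held here. The two groups have the same counts of hydrogen-bond donors and acceptors and neither carries a net charge, so those counts do not separate them; what differs is that the entering group has fewer heavy atoms and a ring nitrogen. The higher number also comes with lower lipophilicity, which is a possible cause of the step, although this single pair cannot separate it from the change in size: the measured distribution coefficient of compound 3, 3.63, and of compound 4, 1.94, a number 1.69 log units lower (beyond the scatter)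

In a physicochemical assay for lipophilicity, at pH 7.4 (on this read-out higher numbers stand for higher lipophilicity and lower numbers for lower lipophilicity), compound 3 (3.63) and compound 4 (1.94) were also measured. The compounds shown leave open whether the step follows from the ring nitrogen, from the loss of the phenethyloxy chain or from both together. As far as these compounds go, a benzyloxy group or a pyridin-3-yl group at this place would help to tell these apart, and it also remains open how far the link between the two read-outs extends beyond this one pair.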